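This account rests on a few compounds, and the source may have more. Where it says the series, first, only, none or still open, it means among the compounds named here.

Compound 1 `O=c1[nH]c2ccccc2cc1-c1nc2cc(F)ccc2[nH]1` is the only one of the three measured compounds that gives a number in a functional assay on HepG2 cells (Homo sapiens) for cytotoxicity, read by MTT assay, with a stated time of 48 h (on this read-out higher numbers stand for weaker inhibition and lower numbers for stronger inhibition), where compound 1 gives 15200 nM. Compound 3 `Cc1ccc2[nH]c(=O)c(-c3nc4cc(F)ccc4[nH]3)cc2c1` reaches only a limit in this assay, where compound 3 gives > 100000 nM. Compound 2 `Cc1ccc2[nH]c(=O)c(-c3nc4cc(C)c(C)cc4[nH]3)cc2c1` likewise reaches only a limit, and in this assay compound 2 gives > 100000 nM. The difference between the cores of compound 2 and compound 3 is not broken down here. Within the data shown here, the one measured step is hydrogen in place of methyl on an aromatic carbon, which gives an at least 6.5-fold lower number from compound 3 to compound 1 (0.81 log units; beyond the scatter); how far it really goes is hidden because of the limit of > 100000 nM in this assay, at which 2 of the 3 values shown sit. Compound 4 `Cc1cc2nc(-c3cc4ccccc4[nH]c3=O)[nH]c2cc1C` has not been measured; it differs from compound 2 by hydrogen in place of methyl on an aromatic carbon, the same change as that from compound 3 to compound 1. From compound 2 to compound 4 a step of about an at least 3.3-fold lower number from compound 2 to compound 4 (0.52 log units; beyond the scatter) is expected in this assay, resting on the step from compound 3 to compound 1, an at least 6.5-fold lower number from compound 3 to compound 1 (0.81 log units; beyond the scatter), which pulled a value down from the limit. Compound 4 is therefore estimated at 30000 nM in this assay, within a range from 8000 nM to 150000 nM.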

Compound 4, half-maximal inhibitory concentration: > 100000 nM
Compound 4 was reported as a limit (the forecaster's own chance of this, stated with the estimate: 35%); middle value at least 3.3-fold (0.52 log units) from the limit.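

In this assay compound 4 also reaches only a limit, so no new step can be read between compound 2 and compound 4, because both values are limits: the limit of > 100000 nM in this assay, at which 3 of the 4 values shown sit. The compounds shown leave open whether hydrogen in place of methyl on an aromatic carbon changes the number at all from compound 2 to compound 4, and how large that change really is from compound 3 to compound 1.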